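Fluorobenzyl for Cyclopropylmethyl on the Aryl Amine Nitrogen

This account rests on a few compounds, and the source may have more. Where it says the series, first, only, none or still open, it means among the compounds named here.

Measured so far:
compound 1 `COc1cc(N(CC2CC2)c2ccc(F)c3ccccc23)cnc1C(=O)[C@H]1C[C@@H]1C(=O)O` gives 26.5 nM
compound 2 `CCCN(c1cnc(C(=O)[C@H]2C[C@@H]2C(=O)O)c(OC)c1)c1ccc(F)c2ccccc12` gives 7.09 nM
compound 3 `COc1cc(N(CC2CC2)c2cccc(C(F)(F)F)c2)cnc1C(=O)[C@H]1C[C@@H]1C(=O)O` gives 52.4 nM

In an assay on isolated protein for inhibition of leukotriene C4 synthase (Homo sapiens), read by LC-MS, with stated times of 45 min and 20 min (a higher number here means a weaker inhibitor, a lower number a stronger inhibitor), compound 3 has the highest of the three numbers, but compound 1 lies within the scatter of it, and only compound 2 stands clearly apart. Compound 4 `COc1cc(N(Cc2ccc(F)cc2)c2cccc(C(F)(F)F)c2)cnc1C(=O)[C@H]1C[C@@H]1C(=O)O` differs from compound 3 by 4-fluorophenyl in place of cyclopropyl on a saturated chain carbon bound to a nitrogen on an aromatic ring. Going by the values given here, the one measured step at that position, a 3.7-fold lower number from compound 1 to compound 2 (0.57 log units; beyond the scatter), exchanges two small saturated groups; it shows the site tolerates change but does not speak to an aromatic ring entering there. Among the compounds with values here, with no step bearing directly on this change, compound 4 is expected to stay near compound 3, giving an estimated 40 nM within 12 nM to 150 nM. The expected step is a 1.3-fold lower number from compound 3 to compound 4 (0.12 log units; within the scatter).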

Compound 4, half-maximal inhibitory concentration: 157 nM
For compound 4 the middle estimate is 3.9-fold (0.59 log units) below the measured one; the whole stated range lies below it.
By their numbers in this assay, from the lowest: compound 2; then compounds 1 and 3 (each within the scatter of the next); then compound 4.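

Placing 4-fluorophenyl in place of cyclopropyl on a saturated chain carbon bound to a nitrogen on an aromatic ring gives a 3.0-fold higher number from compound 3 to compound 4 (0.48 log units; beyond the scatter) in this assay. An aromatic ring is therefore accepted at this position, but at a cost, whereas the earlier step with ethyl, on a different aryl group, went the other way, a 3.7-fold lower number from compound 1 to compound 2 (0.57 log units; beyond the scatter). Nothing measured here accounts for this loss.

On these data alone, whether the loss belongs to the ring or to its fluorine remains open, and an unsubstituted benzyl would separate the two. Also open, as far as these compounds go, is whether a propyl chain would bring the gain seen in compound 2 to the core of compound 3.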